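Reverting the piperidine amine toward a phenylethyl substituent

This account rests on a few compounds, and the source may have more. Where it says the series, first, only, none or still open, it means among the compounds named here.

Within the data shown here, compound 2 `CC#CCN(C)C1CCN(CCCc2c[nH]c3ccc(-n4cnnc4)cc23)CC1` gives 81 nM in an assay on CHO cells for binding affinity to 5-hydroxytryptamine receptor 1B (Homo sapiens) (a lower number here means a stronger inhibitor, a higher number a weaker inhibitor), and stands lowest of the two numbers measured so far. Compound 1 `COC[C@H](NC1CCN(CCCc2c[nH]c3ccc(-n4cnnc4)cc23)CC1)c1ccccc1` gives 210 nM in this assay. Compound 3 `C[C@H](NC1CCN(CCCc2c[nH]c3ccc(-n4cnnc4)cc23)CC1)c1ccccc1` differs from compound 2 by (1-phenylethyl)amino in place of (but-2-yn-1-yl)(methyl)amino on a saturated ring carbon. Among the measured compounds shown here, the one step that bears on this change is a 2.6-fold lower number from compound 1 to compound 2 (0.41 log units; beyond the scatter), a modest drop on going to the small alkyne amine; compound 3 moves back toward the aryl-bearing amine of compound 1, so a rise of similar size is expected, a 2.2-fold higher number from compound 2 to compound 3 (0.35 log units; beyond the scatter). Compound 3 is therefore estimated at 180 nM, within 70 nM to 450 nM.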

Compound 3, half-maximal inhibitory concentration: 95 nM
Compound 3: the middle estimate sits 1.9-fold (0.28 log units) above what was measured; the measured number falls inside the stated range.
By their numbers in this assay, from the lowest: compounds 2 and 3 (each within the scatter of the next); then compound 1.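

In this assay, an aromatic ring on the amine does not by itself set the number: (1-phenylethyl)amino and (but-2-yn-1-yl)(methyl)amino are not separated on the saturated ring carbon (a 1.2-fold higher number from compound 2 to compound 3 (0.07 log units; within the scatter)). Within the aryl-bearing amines, hydrogen in place of methoxy on the saturated chain carbon gives a step beyond the scatter (a 2.2-fold lower number from compound 1 to compound 3 (0.34 log units; beyond the scatter)). No measurement given here bears on the reason for either step.

Open, on these data alone, is whether a hydroxyl or a fluorine in place of that methoxy would match hydrogen, and whether the opposite defined stereocentre of (1-phenylethyl)amino would hold the number.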